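From 4-fluorophenyl to 4-bromophenyl

The source may report more compounds than this note shows. Statements on the series, on what has been measured and on what is new or still open speak of the compounds shown alone.

Within the data shown here, in a functional assay on L1210 cells (Mus musculus) (on this read-out lower numbers stand for stronger inhibition and higher numbers for weaker inhibition), compound 2 (`O=C(/C=C/c1ccc(F)cc1)Oc1ccc(/C=C2\CCCCC2=O)cc1`) reads 30900 nM, the lower of the two numbers so far, while compound 1 (`Cc1ccc(/C=C/C(=O)Oc2ccc(/C=C3\CCCCC3=O)cc2)cc1`) reads 202000 nM. Compound 3 (`O=C(/C=C/c1ccc(Br)cc1)Oc1ccc(/C=C2\CCCCC2=O)cc1`) has bromo in place of fluoro on an aromatic carbon, para to a large group: bromo in place of fluoro on an aromatic carbon. Among the measured compounds shown here, the only measured step bearing on this is the modest 6.5-fold lower number from compound 1 to compound 2 (0.82 log units; beyond the scatter), fluoro in place of methyl. For the measured compounds named here, no measured compound carries bromo, so that step offers only a rough size. An expected modest rise gives a 1.9-fold higher number from compound 2 to compound 3 (0.29 log units; within the scatter). For compound 3 the estimated value is 60000 nM, with an expected range of 20000 nM to 200000 nM.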

Compound 3, half-maximal inhibitory concentration: 127000 nM
Compound 3: middle estimate off by 2.1-fold (0.33 log units), on the low side; the range from low to high includes it.
By their numbers in this assay, from the lowest: compound 2; then compounds 3 and 1 (each within the scatter of the next).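

In this assay, the aromatic carbon para to a large group does not treat the two halogens alike: a 4.1-fold higher number from compound 2 to compound 3 (0.61 log units; beyond the scatter). Among these compounds, the lower number of compound 2 therefore does not extend to bromo, and replacing methyl with bromo gives a 1.6-fold lower number from compound 1 to compound 3 (0.20 log units; within the scatter), leaving fluoro as the only group of the three that stands apart. Nothing available accounts for this difference between fluoro and bromo.

Going by these compounds, whether chloro would read closer to fluoro or to bromo remains open. So does how a methoxy group or an amine would read on this carbon.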